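Benzamido to acetamido on a shared core

The source may hold more compounds than are shown below. What is called first, only, known or untested is meant among the compounds shown, and "the series" means these compounds.

Measured so far in a functional assay on SiHa cells (Homo sapiens) for inhibition; a higher number here means a weaker inhibitor, a lower number a stronger inhibitor:
- compound 1 `COc1cc(/C=C/C(=O)c2cccc(NC(=O)c3c(Cl)cccc3Cl)c2)ccc1O` gives 3.56 ug/mL
- compound 2 `COc1cc(/C=C/C(=O)c2cccc(NC(=O)c3ccccc3)c2)ccc1O` gives 4.57 ug/mL

On these numbers, compound 2 stands level with compound 1 within the scatter of this assay. The next compound, compound 3 `COc1cc(/C=C/C(=O)c2cccc(NC(C)=O)c2)ccc1O`, is not yet measured. It differs from compound 2 as follows: methyl in place of phenyl on a carbonyl carbon. In words, it carries methyl in place of phenyl on a carbonyl carbon, so that benzamido gives way to acetamido.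

Among the measured compounds shown here, only one measured step bears on this change, and it does so indirectly. That step is a 1.3-fold higher number from compound 1 to compound 2 (0.11 log units; within the scatter), and it lies within the scatter. It replaces 2,6-dichlorophenyl with phenyl on a carbonyl carbon, so the ring stays in place in both compounds. For the measured compounds named here, no measured compound shows what happens when that ring is lost altogether, and the data therefore give no direction for the change. A step beyond the scatter is not expected, though the uncertainty is wide.

The estimated step is a 1.1-fold higher number from compound 2 to compound 3 (0.04 log units; within the scatter). For compound 3 the expected value is 5 ug/mL, with an estimated range of 2.2 ug/mL to 11 ug/mL.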

Compound 3, half-maximal inhibitory concentration: 15.8 ug/mL
The estimate for compound 3 lay 3.2-fold (0.50 log units) below the measured number, outside the stated range (above it).
By their numbers in this assay, from the lowest: compounds 1 and 2 (each within the scatter of the next); then compound 3.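

In this assay, this position on the carbonyl carbon of the amide proves sensitive to the change, which the earlier pair could not show because both of its members keep a ring there. Putting methyl in place of phenyl gives a 3.5-fold higher number from compound 2 to compound 3 (0.54 log units; beyond the scatter), and putting methyl in place of 2,6-dichlorophenyl gives a 4.4-fold higher number from compound 1 to compound 3 (0.65 log units; beyond the scatter); both steps lie beyond the scatter, so compound 3 is a weaker inhibitor than either ring-bearing compound, although those two stand level with each other. The ring on this carbonyl carbon therefore counts for more here than the two chlorines on it do, but nothing available explains why the step from phenyl to methyl raises the number.

The compounds shown jump from a six-carbon aromatic ring straight to a single carbon, so they leave open whether the loss follows from removing the aromatic ring or simply from removing carbon atoms. A cyclohexyl group or a longer chain such as butyl on the same carbonyl carbon would separate these two readings, and a pyridyl ring would test whether an all-carbon ring is needed at all.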